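A Fluorine Added to the Benzylamino Arm of Compound 1

The source may hold more compounds than are shown below. What is called first, only, known or untested is meant among the compounds shown, and "the series" means these compounds.

Compound 1 `O=C(c1nn(-c2ccccc2)c2c1CC(NCc1ccccc1)CC2)N1CCCCC1` was examined in an assay on HEK293 cells for displacement of a labelled ligand from Sigma non-opioid intracellular receptor 1 (Homo sapiens), read by scintillation counting, with a stated time of 120 min (on this read-out lower numbers stand for stronger inhibition and higher numbers for weaker inhibition), where compound 1 gives 631 nM. Of the two compounds with a numerical result in this assay, compound 1 stands at the higher number. Its nearest neighbour, compound 2 `O=C(c1c2c(nn1-c1ccccc1)CCC(NCc1ccccc1)C2)N1CCCCC1`, gives 39.8 nM in this assay, a clearly lower number, and the gap between the two lies well beyond the usual scatter of such measurements. Compound 3 `CCCn1nc(C(=O)N(C)C)c2c1CCC(OCc1ccc(F)cc1)C2` gives > 10000 nM in this assay, and this is a limit of the assay rather than a number: the limit of > 10000 nM in this assay, at which 1 of the 3 values shown sits.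

Compound 4 `O=C(c1nn(-c2ccccc2)c2c1CC(NCc1ccc(F)cc1)CC2)N1CCCCC1` differs from compound 1 in a single place: fluoro in place of hydrogen on an aromatic carbon. Within the data shown here, no measured pair in this set shows this particular change, so there is no step to lean on. The step from compound 1 to compound 4 in this assay is expected to be small, not clearly beyond the scatter in either direction; the expected step is a 1.3-fold lower number from compound 1 to compound 4 (0.10 log units; within the scatter). Compound 4 is therefore estimated to give 500 nM in this assay, with a likely range from 200 nM to 1600 nM.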

Compound 4, inhibition constant: 158 nM
Estimate against measurement, compound 4: 3.2-fold (0.50 log units) above, and the stated range ends above it.
By their numbers in this assay, from the lowest: compound 2; then compound 4; then compound 1. At a limit, above all of these: compound 3.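

In this assay, fluoro in place of hydrogen on the benzylamino arm brings a 4.0-fold lower number from compound 1 to compound 4 (0.60 log units; beyond the scatter). Among these compounds, this is the first step in the set that isolates a single change, and it shows that the aromatic carbon para to a large group on this arm is not indifferent to substitution: even one added fluorine atom moves the result beyond the scatter, towards stronger inhibition, though the step is modest in size. Nothing measured here bears on why the number falls with this change.

What the compounds shown leave open is whether this step belongs to fluoro itself or would also appear with another group at the same place, such as chloro, methoxy or a nitrile, and whether fluoro elsewhere on the same ring would do the same. From the compounds shown here alone, it is also open whether the change from benzyl to 4-fluorobenzyl would carry over to compound 2, which bears the same benzylamino arm on a differently arranged core, or whether the step holds only on the core of compound 1.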